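Methyl in place of nitro: working notes on the series

The compounds below may be only part of what the source reports. "The series", "measured", "known", "first", "only" and "open" are said of these compounds alone.

Readings so far in a functional assay on MCF7 cells (Homo sapiens) for cytotoxicity, read by MTT assay, with a stated time of 72 h; on this read-out lower numbers stand for stronger inhibition and higher numbers for weaker inhibition
Compound 1 `CNC(=O)c1cc(Oc2ccc(C(=O)/C=C/c3ccc([N+](=O)[O-])cc3)cc2)ccn1` gives "not determined" (no result reported) 
Compound 2 `CNC(=O)c1cc(Oc2ccc(C(=O)/C=C/c3ccc(OC)cc3)cc2)ccn1` gives "not determined" (no result reported) 
Compound 3 `CNC(=O)c1cc(Oc2ccc(/C=C/C(=O)c3ccc([N+](=O)[O-])cc3)cc2)ccn1` gives 54300 nM 

Going by the values given here, compound 3 at 54300 nM is the only number available, so it cannot yet be ranked against anything. Among the compounds with values here, the two other entries carry no result, which leaves no measured step between compounds to serve as a guide.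

Compound 4 `CNC(=O)c1cc(Oc2ccc(/C=C/C(=O)c3ccc(C)cc3)cc2)ccn1` keeps the core of compound 3 and has methyl in place of nitro on an aromatic carbon, para to a large group (methyl in place of nitro on an aromatic carbon).

With compound 3 at 54300 nM as the sole anchor, no step beyond the scatter is expected in this assay and neither direction is favoured. The estimated change is a 1.1-fold lower number from compound 3 to compound 4 (0.04 log units; within the scatter) and it is expected to stay within the usual scatter, though the lack of any measured step keeps the range wide.

For compound 4 the estimated value is 50000 nM, with an expected range from 15000 nM to 120000 nM in this assay.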

Compound 4, half-maximal inhibitory concentration: 24900 nM
For compound 4 the middle estimate is 2.0-fold (0.30 log units) above the measured one, within the range that was stated.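

In this assay the series now has a measured step: methyl in place of nitro on an aromatic carbon, para to a large group, gives a 2.2-fold lower number from compound 3 to compound 4 (0.34 log units; beyond the scatter), a modest change that lies beyond the scatter. At this position, the 4-nitrophenyl group is therefore not required for a measurable number, and 4-methylphenyl gives the lower one of this pair. No independent measurement bears on why the number moves.

As far as these compounds go, a single pair sets no trend, so it remains open whether an amine or a carboxylic acid at this position would continue or reverse the step. Steps involving compound 1 and compound 2 cannot be read, leaving the effect of the other arrangement of the shared core unresolved.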